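A New Amide Group at the Assay Limit

The source may report more compounds than this note shows. Statements on the series, on what has been measured and on what is new or still open speak of the compounds shown alone.

Compound 1 `CCCCNC(=O)COc1ccc(C(=O)c2c(CCCC)oc3ccccc23)cc1` and compound 2 `CCCCc1oc2ccccc2c1C(=O)c1ccc(OCC(=O)N2CCCCC2)cc1` share a core and were both tested in a functional assay on MCF7 cells (Homo sapiens) for antiproliferative activity, read by MTT assay, with a stated time of 24 h; a higher number here means a weaker inhibitor, a lower number a stronger inhibitor. In this assay compound 1 gives > 50000 nM, which is a limit and not a number. Compound 2 gives > 50000 nM, which is also a limit, so it has no exact position on the scale. Among the compounds with values here, the only measured step, a step that the two limits leave unreadable from compound 1 to compound 2, therefore offers no size to carry forward.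

Compound 3 `CCCCc1oc2ccccc2c1C(=O)c1ccc(OCC(=O)Nc2cccc(OC)c2)cc1` keeps the core of compound 2 but has (3-methoxyphenyl)amino in place of piperidin-1-yl on a carbonyl carbon. Within the data shown here, the only measured guide is the limit of > 50000 nM in this assay, at which 2 of the 2 values shown sit. No change beyond the scatter and no clear direction are expected, so the estimated step is a number no higher from compound 2 to compound 3 (the limit leaves the size open). For compound 3 the estimate is 50000 nM, with an expected range from 20000 nM to 100000 nM.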

Compound 3, half-maximal inhibitory concentration: 38500 nM
For compound 3 the middle estimate is 1.3-fold (0.11 log units) above the measured one; measured number inside the range.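

Compound 3 is the only one of the three shown with an exact number in this assay, so changes at this carbonyl carbon now have a step with a readable floor. Replacing piperidin-1-yl with (3-methoxyphenyl)amino gives an at least 1.2-fold lower number from compound 2 to compound 3 (0.11 log units; that floor lies within the scatter), and placing 3-methoxyphenyl instead of butyl on the amide-type nitrogen gives an at least 1.2-fold lower number from compound 1 to compound 3 (0.11 log units; that floor lies within the scatter). Both floors lie within the scatter, so they do not establish a real change, and the true sizes stay open: the limit of > 50000 nM in this assay, at which 2 of the 3 values shown sit.

Still open, from the compounds shown here alone, is whether the methoxy group on the aromatic ring matters at all, which a plain phenylamino group at the same place could test. An amine-bearing chain or a carboxylic acid on the amide nitrogen would show whether this position can move the value further.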